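The source may report more compounds than this note shows. Statements on the series, on what has been measured and on what is new or still open speak of the compounds shown alone.

The account begins with compound 1 `COc1ccc(Oc2ccc3c(NCCCNCc4cc(F)ccc4OC)ccnc3c2)cc1` and its companion compound 2 `COc1cccc(CNCCCNc2ccnc3cc(Oc4cccc(N(C)C)c4)ccc23)c1O`, the two compounds for which numbers exist. In a physicochemical assay for acid dissociation, compound 1 gives 9.28, and compound 2 gives 9.28 in the same this assay; the two values agree at the digits shown, and the gap between them lies within the scatter, so neither stands apart from the other.

The next compound to be examined is compound 3 `CCC(CC)c1ccc2c(NCCCNCc3cc(F)ccc3OC)ccnc2c1`. Its difference from compound 1 is pentan-3-yl in place of 4-methoxyphenoxy on an aromatic carbon.

For the measured compounds named here, no step between measured compounds is available for this kind of exchange, and the change sits on the shared core, away from the chain that carries the amine. For that reason the step of a number 0.02 log units higher from compound 1 to compound 3 (within the scatter) is expected to be none beyond the scatter, in either direction. Compound 3 is therefore expected to give about 9.3 in this assay, within a range from 8.9 to 9.7.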

Compound 3, acid dissociation constant: 9.47
Compound 3: middle estimate off by 0.17 log units, on the low side, and the stated range covers the measured number.
By their numbers in this assay, from the lowest: compounds 1, 2 and 3 (each within the scatter of the next).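

For the compounds shown here, the exchange of 4-methoxyphenoxy for pentan-3-yl, on an aromatic carbon of the shared core, gives in this assay a number 0.19 log units higher from compound 1 to compound 3 (within the scatter) and so provides the first single-place step at this position. The step stays within the scatter even though the exchange removes a six-membered aromatic ring, both oxygens and both hydrogen-bond acceptors, and the entering group has 5 heavy atoms where the leaving group has 9. No measurement offered here accounts for the size of this step.

This single step cannot show whether the same holds for other groups at this position, such as a dimethylamino group, a carboxylic acid or a primary amine. It also leaves open what a longer chain in place of the propane-linked amine chain would do to the number in this assay.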